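The source may report more compounds than this note shows. Statements on the series, on what has been measured and on what is new or still open speak of the compounds shown alone.

Measured in an assay on HeLa cells for displacement of a labelled ligand from adenosine receptor A3 (Homo sapiens), with a stated time of 180 min, tested at 10 uM; a higher number here means more inhibition at the concentration tested (going by the name of the read-out), a lower number less inhibition:

compound 1 `CC1=C(C(=O)OC(C)C)C(c2ccoc2)NC(=S)N1`: 23%
compound 2 `CCOC(=O)C1=C(C)N(C)C(=O)NC1c1ccoc1`: 1%
compound 3 `CC1=C(C(=O)OC(C)C)C(c2ccsc2)NC(=S)N1`: 3%

Compound 3 carries the change thiophen-3-yl in place of furan-3-yl on a saturated ring carbon relative to compound 1, and this gave a number 20 percentage points lower from compound 1 to compound 3 (beyond the scatter). Compound 2 stands lowest of the three in this assay; its gap to compound 3 is within the scatter, its gap to compound 1 beyond it. How the core of compound 2 differs from that of compound 1 is not broken down here.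

Compound 4 `CCOC(=O)C1=C(C)N(C)C(=O)NC1c1ccsc1` is not yet measured. It relates to compound 2 by thiophen-3-yl in place of furan-3-yl on a saturated ring carbon, the same kind of change as from compound 1 to compound 3, though the surroundings differ: here the saturated ring carbon is next to the ring atom that bears an ethoxycarbonyl group rather than an isopropoxycarbonyl group, and it also lies three ring bonds from the ring atom that bears a methyl group.

From compound 2 to compound 4 a step of no change at the digits printed from compound 2 to compound 4 (within the scatter) is expected, because compound 2 with 1% leaves almost no room for a drop of the size seen as a number 20 percentage points lower from compound 1 to compound 3 (beyond the scatter). For compound 4 the estimated value is 1%, expected between -6% and 8%.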

Compound 4, a percentage reported as inhibition, at one concentration (the size of the read-out at that concentration, not a potency): 3%
Compound 4: the middle estimate sits 2 percentage points below what was measured, and the stated range covers the measured number.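

In this assay, thiophen-3-yl in place of furan-3-yl does not carry over as one fixed step from the core of compound 1 to the core of compound 2: the same change on two cores in this assay, a number 20 percentage points lower (beyond the scatter) from compound 1 to compound 3 and a number 2 percentage points higher (within the scatter) from compound 2 to compound 4, 22 percentage points apart, beyond the scatter of two such steps

On the second core the change gives a number 2 percentage points higher from compound 2 to compound 4 (within the scatter). Compound 2 gives 1%, close to the bottom of the read-out, where a drop could hardly show; the gap between the two steps therefore does not show that the change itself acts differently on that core, nor which feature of the two cores would matter.

From the compounds shown here alone, whether the step recurs on a core that starts from a higher value stays open. Also open, going by these compounds, is how a phenyl ring or a longer chain on the saturated ring carbon would read.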